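The source may hold more compounds than are shown below. What is called first, only, known or untested is meant among the compounds shown, and "the series" means these compounds.

Measured so far in an ADME assay on HeLa cells (Homo sapiens) for cytotoxicity, read by microscopy; on this read-out lower numbers stand for higher toxicity in this test and higher numbers for lower toxicity in this test:
compound 1 `CSc1nc(NCCCNc2ccnc3cc(Cl)ccc23)c(C#N)c(-c2ccccc2)n1`: 100000 nM
compound 2 `CSc1nc(NCCCCNc2ccnc3cc(Cl)ccc23)c(C#N)c(-c2ccccc2)n1`: 100000 nM

Compound 2 stands level with compound 1 at the digits recorded; the two values differ by nothing beyond the scatter, so no word of order between them is warranted. Going by the values given here, both sit at the same reading in this assay, and with only two measured compounds and no step between compounds differing in one place, the series offers no guide yet to how any single change moves this read-out.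

Compound 3 `CSc1nc(NCCCCNc2ccnc3cc(Cl)ccc23)c(C#N)c(-c2ccc([N+](=O)[O-])cc2)n1` is the next compound, not yet measured. It differs from compound 2 by nitro in place of hydrogen on an aromatic carbon.

Among the compounds with values here, no measured step is available for this or any other change. In this assay the expectation is therefore that compound 3 stays near the common value of compound 1 and compound 2, with no step beyond the scatter, or at most a small shift toward a lower reading. The step from compound 2 to compound 3 is estimated as a 1.3-fold lower number from compound 2 to compound 3 (0.10 log units; within the scatter). For compound 3 the estimated value is 80000 nM, with a range from 25000 nM to 100000 nM.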

Compound 3, minimum cytotoxic concentration: 4000 nM
Compound 3: middle estimate off by 20-fold (1.30 log units), on the high side, and the stated range ends above it.
By their numbers in this assay, from the lowest: compound 3; then compounds 1 and 2 (each within the scatter of the next).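

In this assay the change from phenyl to 4-nitrophenyl gives a 25-fold lower number from compound 2 to compound 3 (1.40 log units; beyond the scatter) and so moves the read-out beyond the scatter, toward higher toxicity in this test. Going by these compounds alone, until now the series showed a single level, so this is the first sign that the read-out responds to a change in structure, and that the aromatic carbon para to a large group is a place where one substituent can matter. Nothing measured here bears on why nitro has this effect.

From the compounds shown here alone, whether the step belongs to nitro in particular remains open, as an amine, a methoxy group or a chlorine atom on the same carbon would be needed to tell whether other substituents move the read-out in the same way or to the same extent. Also open, going by these compounds, is whether the same change carries over to the shorter chain of compound 1, since the step is known only on the chain of compound 2, and a single step cannot show how far it depends on the rest of the molecule.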